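The source may report more compounds than this note shows. Statements on the series, on what has been measured and on what is new or still open speak of the compounds shown alone.

Measured compounds in a functional assay on mitochondria from heart for inhibition of peroxisomal acyl-coenzyme A oxidase 1 (Rattus norvegicus); on this read-out lower numbers stand for stronger inhibition and higher numbers for weaker inhibition:
compound 1 `Cc1nc2cc(OC[C@H](O)CN3CCN(Cc4noc(-c5ccc(C(F)(F)F)cc5)n4)CC3)ccc2s1` gives 380 nM;
compound 2 `Cc1nc2cc(OC[C@H](O)CN3CCN(Cc4csc(-c5ccc(C(F)(F)F)cc5)n4)CC3)ccc2s1` gives 1300 nM;
compound 3 `Cc1nc2cc(OC[C@H](O)CN3CCN(Cc4noc(-c5ccc(Cl)cc5Cl)n4)CC3)ccc2s1` gives 130 nM.

Compound 3 carries the lowest of the three numbers, and its two steps to the others are both beyond the scatter: compound 2 shows the highest value of the set, while the nearest neighbour, compound 1, is separated from compound 3 by the step of a 2.9-fold lower number from compound 1 to compound 3 (0.47 log units; beyond the scatter), which is a modest change brought by the 2,4-dichlorophenyl group in place of the 4-(trifluoromethyl)phenyl group.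

Compound 4 `Cc1nc2cc(OC[C@H](O)CN3CCN(Cc4noc(-c5cccc(F)c5)n4)CC3)ccc2s1` differs from compound 3 in one place: 3-fluorophenyl in place of 2,4-dichlorophenyl on an aromatic carbon. Within the data shown here, the only measured step that bears on this position is a 2.9-fold lower number from compound 1 to compound 3 (0.47 log units; beyond the scatter), in which the 2,4-dichlorophenyl group went with the lower number. No other aryl variant at this carbon has been measured, so the direction is read from that single step: removing the 2,4-dichlorophenyl group is expected to reverse it, giving a higher number by a modest step, a 3.8-fold higher number from compound 3 to compound 4 (0.59 log units; beyond the scatter). Compound 4 is therefore expected to show about 500 nM in this assay, within a range from 150 nM to 1800 nM.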

Compound 4, half-maximal inhibitory concentration: 13400 nM
Compound 4: middle estimate off by 27-fold (1.43 log units), on the low side; the whole stated range lies below it.
By their numbers in this assay, from the lowest: compound 3; then compound 1; then compound 2; then compound 4.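

The aryl group on this carbon of the five-membered ring matters far more than the first step suggested: in this assay the 3-fluorophenyl group brings a large change (a 100-fold higher number from compound 3 to compound 4 (2.01 log units; beyond the scatter)) and an equally clear one against the 4-(trifluoromethyl)phenyl group (a 35-fold higher number from compound 1 to compound 4 (1.55 log units; beyond the scatter)). Compound 1 and compound 3 stand only a modest step apart, so two different aryl groups are accepted here with limited change, while this third one moves the number much further. No measurement at hand accounts for the size of this change.

The 3-fluorophenyl group differs from the 2,4-dichlorophenyl group in both the halogen and its place on the ring, and the compounds shown do not separate these two changes. On these data alone, whether 3-chlorophenyl, 4-fluorophenyl or plain phenyl would stand nearer to compound 3 or to compound 4 remains open.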